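A trifluoromethyl added to the aromatic ring of compound 2

This account rests on a few compounds, and the source may have more. Where it says the series, first, only, none or still open, it means among the compounds named here.

Compound 1 `Nc1ccccc1NC(=O)CCCCCCc1nc(-c2ccccc2)no1` gives 23900 nM here
Compound 2 `O=C(CCCCCCc1nc(-c2ccccc2)no1)C(F)(F)F` gives 7680 nM here

Compound 2 gives 7680 nM in a functional assay on A549 cells (Homo sapiens) for antiproliferative activity, read by MTT assay, with a stated time of 72 h (on this read-out lower numbers stand for stronger inhibition and higher numbers for weaker inhibition), and compound 1 gives 23900 nM there, so compound 2 holds the lower of the two numbers. Among the measured compounds shown here, the only measured step is a 3.1-fold lower number from compound 1 to compound 2 (0.49 log units; beyond the scatter) and it replaces (2-aminophenyl)amino with trifluoromethyl on a carbonyl carbon.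

Compound 3 `O=C(CCCCCCc1nc(-c2ccc(C(F)(F)F)cc2)no1)C(F)(F)F` keeps that carbonyl end of compound 2 and changes elsewhere. The difference is trifluoromethyl in place of hydrogen on an aromatic carbon with trifluoromethyl in place of hydrogen on an aromatic carbon, para to a large group. For the measured compounds named here, the measured step lies at another place in the structure, and no measured compound carries a substituent on this ring. The data therefore give neither a size nor a direction for this change, and no step beyond the scatter is expected in this assay from this evidence. The estimate rests on compound 2 with its 7680 nM as the anchor. This expectation amounts to an estimated 1.2-fold lower number from compound 2 to compound 3 (0.07 log units; within the scatter) and nothing firmer. Compound 3 is expected at 6500 nM with an estimated range from 2500 nM to 16000 nM for its measurement.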

Compound 3, half-maximal inhibitory concentration: 28800 nM
The estimate for compound 3 lay 4.4-fold (0.65 log units) below the measured number, outside the stated range (above it).
By their numbers in this assay, from the lowest: compound 2; then compounds 1 and 3 (each within the scatter of the next).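

In this assay, the aromatic ring that bears only hydrogens in compound 2 proves sensitive to substitution: trifluoromethyl in place of hydrogen on an aromatic carbon, para to a large group, gives a 3.8-fold higher number from compound 2 to compound 3 (0.57 log units; beyond the scatter). Among the compounds shown here, this is the first measured change at this ring, and with the trifluoromethyl on the carbonyl carbon held constant, it shows a weakening of antiproliferative activity, in the opposite direction to a 3.1-fold lower number from compound 1 to compound 2 (0.49 log units; beyond the scatter), the step at the carbonyl end. The data therefore show that the number responds to changes at both places in the structure, but nothing presented accounts for the response at this ring.

One substituent at one position cannot show whether the weakening is specific to trifluoromethyl or would also follow from a fluorine, a methoxy group or an amine in the same place. On these data alone, it also remains open whether the same ring change would give a step of similar size and direction with (2-aminophenyl)amino on the carbonyl carbon, or with a shorter or longer chain joining the two ends.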